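Swapping a small aromatic ring for a larger one

The source may report more compounds than this note shows. Statements on the series, on what has been measured and on what is new or still open speak of the compounds shown alone.

Measured so far:
compound 1, `CN1CCN(CCCN(C[C@H]2Cc3ccccc3CN2)[C@H]2CCCc3cccnc32)CC1`, gives 125 nM
compound 2, `c1cnc(CN(CCCN2CCNCC2)[C@H]2CCCc3cccnc32)nc1`, gives 4320 nM

Both compounds were tested in a functional assay on CCRF-CEM cells for antagonist activity at C-X-C chemokine receptor type 4 (Homo sapiens), read by calcium flux, with stated times of 25 min and 90 s; on this read-out lower numbers stand for stronger inhibition and higher numbers for weaker inhibition. Of the two numbers shown, compound 2 carries the highest, meaning the weakest inhibition; its nearest neighbour is compound 1, whose number is much lower, and the gap between them is beyond the scatter of repeated measurements. Compound 1 and compound 2 differ in more than one place, so that gap cannot be tied to any single change.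

Compound 3, `c1cnc2c(c1)CCC[C@@H]2N(CCCN1CCNCC1)Cc1cc2ccccc2cn1`, has not yet been measured. It is made from compound 2 by one change: isoquinolin-3-yl in place of pyrimidin-2-yl on a saturated chain carbon bound to an amine nitrogen. The rest of the molecule, including the shared core and the chain carrying the amine, is unchanged.

Among the compounds with values here, no measured pair in this set shows what that exact swap does. Since compound 2 sits at the weak end, a modest move toward stronger inhibition in this assay is expected, though the size is uncertain. The expected step is an 8.6-fold lower number from compound 2 to compound 3 (0.94 log units; beyond the scatter). Compound 3 is therefore estimated at 500 nM, with a range from 100 nM to 2500 nM.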

Compound 3, half-maximal inhibitory concentration: 17 nM
For compound 3 the middle estimate is 29-fold (1.47 log units) above the measured one; measured number below the stated range.
By their numbers in this assay, from the lowest: compound 3; then compound 1; then compound 2.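

In this assay, the group on a saturated chain carbon bound to an amine nitrogen proves to matter a great deal: isoquinolin-3-yl in place of pyrimidin-2-yl gives a 250-fold lower number from compound 2 to compound 3 (2.41 log units; beyond the scatter), a large step beyond the usual scatter. Within the data shown here, the earlier pair differed in more than one place, so this is the first single change in the set that can be read, and it shows that inhibition here responds strongly to the group at this position. The change brings in a six-membered aromatic ring of carbon only and replaces a ring with 2 hetero atoms by a larger group with 1 hetero atom, but no measurement shown explains the size of the step.

These changes arrive together, so the compounds shown cannot separate the contribution of the added carbon ring from that of the altered ring nitrogens. As far as these compounds go, a pyridin-2-yl group or a naphthalen-2-yl group at the same place would be informative, and how either would compare with isoquinolin-3-yl remains open.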